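The source may report more compounds than this note shows. Statements on the series, on what has been measured and on what is new or still open speak of the compounds shown alone.

Compound 3 `O=C1/C(=C/c2ccccc2)CCC/C1=C\c1cccc(Br)c1` gives 27.2% in an assay on isolated protein for inhibition of Alpha glucosidase (Homo sapiens), with stated times of 5 min and 15 min, tested at 50 uM (on this read-out higher numbers stand for more inhibition at the one concentration tested (going by the name of the read-out) and lower numbers for less inhibition), the lowest of the three numbers measured; compound 1 `O=C1/C(=C/c2ccccc2)CCC/C1=C\c1ccccc1Cl` gives 43% and compound 2 `Cc1cccc(/C=C2\CCC/C(=C\c3ccccc3)C2=O)c1` gives 47.9%. Compound 4 `O=C1/C(=C/c2ccccc2)CCC/C1=C\c1ccccc1Br` differs from compound 3 by 2-bromophenyl in place of 3-bromophenyl on a double-bonded chain carbon bound to a double-bonded ring carbon. The step that bears on this is a number 15.8 percentage points lower from compound 1 to compound 3 (beyond the scatter), in which a 2-chlorophenyl gave way to a 3-bromophenyl; the change from compound 3 to compound 4 runs the other way, toward a 2-bromophenyl, so a rise of comparable size is expected, which would place compound 4 close to compound 1. The step of a number 20.7 percentage points lower from compound 2 to compound 3 (beyond the scatter) concerns a different exchange and adds little here. Compound 4 is therefore estimated at 42%, within 28% to 56%, an expected step of a number 14.8 percentage points higher from compound 3 to compound 4 (beyond the scatter).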

Compound 4, a percentage reported as inhibition, at one concentration (the size of the read-out at that concentration, not a potency): 46.8%
The estimate for compound 4 lay 4.8 percentage points below the measured number, within the range that was stated.
By their numbers in this assay, from the lowest: compound 3; then compounds 1, 4 and 2 (each within the scatter of the next).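

In this assay, with the same atoms joined differently, 2-bromophenyl in place of 3-bromophenyl gives a number 19.6 percentage points higher from compound 3 to compound 4 (beyond the scatter), so the site of the bromo on this ring counts at this place. By contrast, bromo in place of chloro gives a number 3.8 percentage points higher from compound 1 to compound 4 (within the scatter) and 2-bromophenyl in place of 3-methylphenyl gives a number 1.1 percentage points lower from compound 2 to compound 4 (within the scatter), so neither exchange separates these compounds. Nothing available explains the difference between the two bromophenyl groups.

On these data alone, it remains open how an amine, a carboxylic acid or a methoxy group on this phenyl would read.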